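From compound 2 to compound 3: phenyl for phenethyl

A few compounds are considered here, and "the series" means these few. Any claim that something is new, unique, unknown or untested is made for them only; others in the source may bear on it.

In a functional assay on PC-3 cells (Homo sapiens) for cytotoxicity, read by sulforhodamine B assay, with a stated time of 5 days (a higher number here means a weaker inhibitor, a lower number a stronger inhibitor), compound 1 `O=C(CCCCCCCc1ccccc1)N[C@H]1CCOC1=O` gives 85000 nM as a measured number. As far as these compounds go, compound 2 `O=C(CCCCCCCCCCCc1ccccc1)N[C@H]1CCOC1=O` gives > 100000 nM as a limit of the assay and not as a number, so its exact place on the scale is unknown. Compound 3 `O=C(CCCCCCCCCc1ccccc1)N[C@H]1CCOC1=O` has phenyl in place of phenethyl on a saturated chain carbon, nine bonds along the chain from a carbonyl carbon. Among the measured compounds shown here, no measured step is available for this change, so only a modest move toward a lower number, and possibly none beyond the scatter, is expected in this assay for this comparison. The estimated step of an at least 1.1-fold lower number from compound 2 to compound 3 (0.04 log units; that floor lies within the scatter) is small. For the measured compounds named here, that expectation leans on compound 1 at 85000 nM as the only exact number available. Compound 3 is estimated at 90000 nM with an expected range from 50000 nM to 150000 nM in this assay and may itself report only a limit.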

Compound 3, half-maximal inhibitory concentration: 75000 nM
Estimate against measurement, compound 3: 1.2-fold (0.08 log units) above, within the range that was stated.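

In this assay, phenyl in place of phenethyl on a saturated chain carbon, nine bonds along the chain from a carbonyl carbon, gives an at least 1.3-fold lower number from compound 2 to compound 3 (0.12 log units; that floor lies within the scatter), so this change now has a size, though only as a floor that stays inside the scatter. Compound 2 remains a limit of the assay and not a number: the limit of > 100000 nM in this assay, at which 1 of the 3 values shown sits.

The exact value of compound 3 also links it to compound 1, with a 1.1-fold lower number from compound 1 to compound 3 (0.05 log units; within the scatter), so these two compounds cannot be told apart and no order along the chain is shown.

The compounds shown leave open whether a shorter chain, or an amine or a carboxylic acid in place of the phenyl, would move the number beyond the scatter. As far as these compounds go, how far the true value of compound 2 lies past its limit also stays open.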